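The source may report more compounds than this note shows. Statements on the series, on what has been measured and on what is new or still open speak of the compounds shown alone.

Three compounds share one core in this account, and the numbers on them are few. In an ADME assay on Vero cells (Chlorocebus sabaeus) for cytotoxicity, read by MTT assay, with a stated time of 96 h (on this read-out higher numbers stand for lower toxicity in this test and lower numbers for higher toxicity in this test), compound 1 (`C/C(=N\O)c1ccc2[nH]c(-c3ccc(C(F)(F)F)cc3)nc2c1`) stands as "not determined" (no result reported) and so offers no figure to work from. Compound 2 (`C/C(=N\NC(N)=S)c1ccc2[nH]c(-c3ccccc3)nc2c1`) gives > 100000 nM in this assay as a limit of the assay and not as a number. Compound 3 (`C/C(=N\NC(N)=S)c1ccc2[nH]c(-c3ccc(C(F)(F)F)cc3)nc2c1`) still awaits measurement. It differs from compound 2 by trifluoromethyl in place of hydrogen on an aromatic carbon of a six-membered aromatic ring of carbon only, para to a large group (trifluoromethyl in place of hydrogen on an aromatic carbon). In this assay, for the measured compounds named here, no measured pair shows what such a change does, so the expectation remains loose. The expected shift (an at least 2.0-fold lower number from compound 2 to compound 3 (0.30 log units; that floor lies within the scatter)) is estimated as a moderate one toward lower numbers, somewhat beyond the usual scatter. The result for compound 3 could equally come back as a limit rather than a number. Compound 3 is expected to give 50000 nM as its estimate in this assay with a range from 12000 nM to 100000 nM as the expected span.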

Compound 3, half-maximal cytotoxic concentration: 22000 nM
Compound 3: the middle estimate sits 2.3-fold (0.36 log units) above what was measured; measured number inside the range.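

In this assay, for the compounds shown here, trifluoromethyl in place of hydrogen on an aromatic carbon, para to a large group, now has a measured effect, which no earlier pair could show: an at least 4.5-fold lower number from compound 2 to compound 3 (0.65 log units; beyond the scatter). The change therefore goes with a lower number on this read-out, meaning higher toxicity in this test, and it brings the series its first single figure rather than a limit of the assay. The size of the step remains a floor and not an exact measure, because compound 2 stands at a limit of the assay and not at a number: the limit of > 100000 nM in this assay, at which 1 of the 3 values shown sits.

The compounds shown do not reveal how other groups at this place would compare, whether a single fluorine or chlorine atom, a methoxy group, an amine or a carboxylic acid, so the step cannot be said to belong to trifluoromethyl alone or to extend to any other substituent. From the compounds shown here alone, compound 1 carries the same trifluoromethyl on the shared core but has a different chain, and with compound 1 at "not determined" (no result reported), what that chain contributes in this assay remains open.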